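The compounds below may be only part of what the source reports. "The series", "measured", "known", "first", "only" and "open" are said of these compounds alone.

In a functional assay on HeLa cells (Homo sapiens) for cytotoxicity, read by resazurin assay, with a stated time of 72 h (a lower number here means a stronger inhibitor, a higher number a weaker inhibitor), compound 1 (`O=C(/C=C/c1ccc(OCCCCO[N+](=O)[O-])c(O)c1)OCCCCO[N+](=O)[O-]`) gives 3930 nM. That value lies within the scatter of compound 2 (`COc1cc(/C=C/C(=O)OCCCO[N+](=O)[O-])ccc1OCCCO[N+](=O)[O-]`), which gives 3620 nM, while compound 3 (`O=C(/C=C/c1ccc(O)c(O)c1)OCc1c(-c2ccccc2)no[n+]1[O-]`) gives 1230 nM. The gap between compound 3 and compound 1 lies beyond the scatter, with compound 3 the lower. Compound 4 (`COc1cc(/C=C/C(=O)OCCCCO[N+](=O)[O-])ccc1OCCCCO[N+](=O)[O-]`) departs from compound 1 by one change, methyl in place of hydrogen on an oxygen on an aromatic ring, or hydroxy to methoxy. Compound 2 also carries methoxy, though its chains differ, and compound 2 gives 3620 nM, so no step beyond the scatter is expected in this assay. The expected step, a 1.1-fold lower number from compound 1 to compound 4 (0.05 log units; within the scatter), is small. For compound 4 the estimated value is 3500 nM, within an expected range of 1800 nM to 7000 nM.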

Compound 4, half-maximal inhibitory concentration: 740 nM
Compound 4: middle estimate off by 4.7-fold (0.67 log units), on the high side; measured number outside the range, below it.
By their numbers in this assay, from the lowest: compounds 4 and 3 (each within the scatter of the next); then compounds 2 and 1 (each within the scatter of the next).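

In this assay, among the compounds shown here, the change from hydroxy to methoxy, on an oxygen on an aromatic ring, brings a 5.3-fold lower number from compound 1 to compound 4 (0.73 log units; beyond the scatter) and is the first single change that can be read here. For the compounds shown here, no earlier pair differed in one place, so this position had not been tested on its own. Nothing shown accounts for the size of this step. From the compounds shown here alone, whether an ethyl group or a longer chain on that oxygen would give a similar step remains open. So does whether the step would hold on a core carrying other chains.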